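A few compounds are considered here, and "the series" means these few. Any claim that something is new, unique, unknown or untested is made for them only; others in the source may bear on it.

Measured so far in a functional assay on the whole organism (Tail, strain ICR) with Mus musculus as the target, in the tail flick test, with a stated time of 30 min, at a dose of 25 umol/kg by the oral route; on this read-out lower numbers stand for a weaker effect and higher numbers for a stronger effect at the one dose given:
compound 1 `CSCC[C@H](NC(=O)CN(c1ncnc2c1ncn2C1CCCCO1)C1CC1)C(=O)OCc1ccccc1`: 30%
compound 2 `C[C@H](NC(=O)CN(c1ncnc2c1ncn2C1CCCCO1)C1CC1)C(=O)OCc1ccccc1`: 55.9%
compound 3 `CC(C)(C)OC(=O)NCCCC[C@H](NC(=O)CN(c1ncnc2c1ncn2C1CCCCO1)C1CC1)C(=O)OCc1ccccc1`: 18.3%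

Compound 3 stands lowest of the three in this assay, below compound 1 by a number 11.7 percentage points lower from compound 1 to compound 3 (beyond the scatter) and below compound 2 by a number 37.6 percentage points lower from compound 2 to compound 3 (beyond the scatter). Compound 4 `CC(C)C[C@H](NC(=O)CN(c1ncnc2c1ncn2C1CCCCO1)C1CC1)C(=O)OCc1ccccc1` differs from compound 3 by isopropyl in place of 3-((tert-butoxycarbonyl)amino)propyl on a saturated chain carbon, two bonds along the chain from an amide-type nitrogen and a carbonyl carbon. The step from compound 2 to compound 3, which brought the 3-((tert-butoxycarbonyl)amino)propyl group in, was large and downward; removing it again and leaving isopropyl should recover part of that loss. Compound 1, with (methylsulfanyl)methyl at the same place, sits between compounds 2 and 3. For compound 4 an upward step of a number 19.7 percentage points higher from compound 3 to compound 4 (beyond the scatter) is expected, landing near compound 1. Compound 4 is estimated at 38% (range 22% to 55%).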

Compound 4, a percentage reported as activity, at one dose (the size of the read-out at that dose, not a potency): 26.2%
The estimate for compound 4 lay 11.8 percentage points above the measured number; the range from low to high includes it.
By their numbers in this assay, from the lowest: compounds 3, 4 and 1 (each within the scatter of the next, the first and the last beyond it); then compound 2.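

In this assay, isopropyl at this saturated chain carbon is enough for the drop from hydrogen (a number 29.7 percentage points lower from compound 2 to compound 4 (beyond the scatter)), so that drop does not depend on the 3-((tert-butoxycarbonyl)amino)propyl group. Isopropyl recovers no readable activity from that larger group (a number 7.9 percentage points higher from compound 3 to compound 4 (within the scatter)) and reads the same as (methylsulfanyl)methyl (a number 3.8 percentage points lower from compound 1 to compound 4 (within the scatter)). Compounds 1 and 3 remain the exception to this flat picture, since only they lie beyond the scatter of each other among the substituted compounds.

From the compounds shown here alone, whether a free amine or a carboxylic acid at the end of the chain would read like hydrogen or like isopropyl stays open. Nothing available accounts for the drop from hydrogen.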